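The source may hold more compounds than are shown below. What is called first, only, known or untested is meant among the compounds shown, and "the series" means these compounds.

In a functional assay on Rec1 cells (Homo sapiens) for inhibition, read by luminescence and CellTiter-Glo, with a stated time of 72 h (on this read-out lower numbers stand for stronger inhibition and higher numbers for weaker inhibition), compound 1 (`C=CC(=O)Nc1ccc(Cn2nc(-c3ccc(Oc4ccccc4)cc3)cc2C(=O)OCC)cc1`) gives 2800 nM and compound 2 (`C/C=C/C(=O)Nc1ccc(Cn2nc(-c3ccc(Oc4ccccc4)cc3)cc2CO)cc1`) gives 12200 nM, the higher of the two numbers, with a gap beyond the usual scatter. Compound 3 (`C=CC(=O)Nc1ccc(Cn2nc(-c3ccc(Oc4ccccc4)cc3)cc2CO)cc1`) has vinyl in place of prop-1-en-1-yl on a carbonyl carbon. Going by the values given here, no measured pair shows this change alone. Compound 1 also carries vinyl and gives 2800 nM, so a lower number is expected in this assay. The expected change is modest but beyond the scatter, a 2.4-fold lower number from compound 2 to compound 3 (0.39 log units; beyond the scatter). The estimate for compound 3 is 5000 nM, with a range of 1800 nM to 13000 nM.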

Compound 3, half-maximal inhibitory concentration: 3500 nM
Estimate against measurement, compound 3: 1.4-fold (0.15 log units) above, and the stated range covers the measured number.
By their numbers in this assay, from the lowest: compounds 1 and 3 (each within the scatter of the next); then compound 2.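

In this assay, vinyl in place of prop-1-en-1-yl on a carbonyl carbon gives a 3.5-fold lower number from compound 2 to compound 3 (0.54 log units; beyond the scatter) with the rest of the molecule unchanged, so this position responds to even this small change. With vinyl kept, hydroxymethyl in place of ethoxycarbonyl on an aromatic carbon gives a 1.3-fold higher number from compound 1 to compound 3 (0.10 log units; within the scatter) and so leaves no readable difference. Nothing available here bears on why the vinyl step has this size. Still open, from the compounds shown here alone, is how a longer chain or an amine on the carbonyl carbon would read, and whether a carboxylic acid in place of hydroxymethyl would change the number.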